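Closing the acid chain into a cyclopropane ring

This account rests on a few compounds, and the source may have more. Where it says the series, first, only, none or still open, it means among the compounds named here.

Compound 3 `O=C(O)CCCc1ccc(NCc2cccc(Oc3ccccc3)c2)cc1` gives 59% in a functional assay on CHO cells for agonist activity at Free fatty acid receptor 1 (Homo sapiens), read by a luciferase reporter (a higher number here means a larger maximal response, a lower number a smaller maximal response), the second highest of the three numbers seen: compound 1 `Cc1nc(-c2ccc(C(F)(F)F)cc2)sc1CNc1ccc(CCC(=O)O)cc1` gives 108% and compound 2 `Cc1nc(-c2ccc(C(F)(F)F)cc2)sc1CNc1ccc(C(=O)O)cc1` gives 10%, each set apart from compound 3 beyond the scatter. Compound 4 `O=C(O)[C@@H]1C[C@H]1c1ccc(NCc2cccc(Oc3ccccc3)c2)cc1` carries 2-carboxycyclopropyl in place of 3-carboxypropyl on an aromatic carbon. For the measured compounds named here, the only measured step that touches the acid chain is a number 98 percentage points lower from compound 1 to compound 2 (beyond the scatter), where 2-carboxyethyl became carboxy; the present change replaces an open chain with a three-membered ring rather than cutting the chain back so far, so that step is only a rough guide. A moderate loss rather than a collapse is expected. Compound 4 is therefore estimated at 70%, with a range of 30% to 110%, an expected step of a number 11 percentage points higher from compound 3 to compound 4 (beyond the scatter).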

Compound 4, largest response reached (reported as percent of maximum), in percent of the reference or control that the assay uses: 64%
Compound 4: middle estimate off by 6 percentage points, on the high side; the measured number falls inside the stated range.
By their numbers in this assay, from the lowest: compound 2; then compounds 3 and 4 (each within the scatter of the next); then compound 1.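

In this assay, 2-carboxycyclopropyl in place of 3-carboxypropyl on this aromatic carbon gives a number 5 percentage points higher from compound 3 to compound 4 (within the scatter), so at this position the acid chain can be closed into a three-membered ring without a step beyond the scatter. For the compounds shown here, the only earlier change to this chain, a number 98 percentage points lower from compound 1 to compound 2 (beyond the scatter), was a cut back to carboxy on a different core. Nothing available explains the result.

Still open, going by these compounds, is how a tetrazole in place of the carboxylic acid, or a cyclobutane in place of the cyclopropane, would read. Also open, on these data alone, are the other stereoisomers of the ring and its effect on the core of compound 1.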